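A few compounds are considered here, and "the series" means these few. Any claim that something is new, unique, unknown or untested is made for them only; others in the source may bear on it.

Working notes on the series. The read-out throughout is a functional assay on HepG2 cells (Homo sapiens) for cytotoxicity, read by MTT assay, with a stated time of 48 h; a lower number here means a stronger inhibitor, a higher number a weaker inhibitor. Four compounds belong together here. Compound 1 `CC1=NN(C(=O)COc2ccc(Cl)cc2)C(c2ccccc2O)C1` is recorded in this assay as "not active" (no number reported); no number is given for it. Compound 2 `CC1=NN(C(=O)CN2CCCC2)C(c2ccccc2O)C1` gives 5540 nM in this assay. Compound 3 `O=C(c1ccccc1)N1N=C(c2cc3ccccc3oc2=O)CC1c1ccccc1` gives 36600 nM in this assay, the highest of the two numbers available, and the gap between compound 3 and compound 2 is beyond the usual scatter. Compound 4 `CCN(CC)C1CCN(CC(=O)N2N=C(c3cc4ccccc4oc3=O)CC2c2ccccc2)CC1` has not yet been measured in this assay.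

The change from compound 3 to compound 4 is (4-(diethylamino)piperidin-1-yl)methyl in place of phenyl on a carbonyl carbon. Going by the values given here, no measured step of this kind exists in the set, so the expectation rests on what is in hand: compound 2, whose carbonyl also carries a methylene linked to a nitrogen-containing ring, gives 5540 nM, a lower number than compound 3, while compound 1 with an ether-linked chain is recorded as "not active" (no number reported). Among the compounds with values here, on that basis a moderate step downward in this assay is expected, a 3.1-fold lower number from compound 3 to compound 4 (0.48 log units; beyond the scatter), though with wide uncertainty given only two numbers.

Compound 4 is therefore estimated at 12000 nM in this assay, with a likely range from 3000 nM to 40000 nM.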

Compound 4, half-maximal inhibitory concentration: 19300 nM
Beside the measured number, compound 4's estimate is 1.6-fold (0.21 log units) below it; measured number inside the range.
By their numbers in this assay, from the lowest: compound 2; then compounds 4 and 3 (each within the scatter of the next).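

Going by these compounds alone, the first readable step at this position, in this assay, is a 1.9-fold lower number from compound 3 to compound 4 (0.28 log units; within the scatter), for (4-(diethylamino)piperidin-1-yl)methyl in place of phenyl on a carbonyl carbon whose other neighbour is an amide-type nitrogen in a ring. The exchange therefore swaps a six-membered aromatic ring of carbon only, with 6 heavy atoms and 0 hydrogen-bond acceptors, for a group with a six-membered non-aromatic ring, 12 heavy atoms and 2 hydrogen-bond acceptors, and the two compounds still cannot be separated in this read-out. No supporting data bear on why the read-out stays within the scatter across so large a change in the group.

The compounds shown leave open whether a carboxylic acid or a primary amine on the same carbonyl carbon, or a longer chain in place of the methylene link, would give a step beyond the scatter. They also leave open whether the same exchange would give a comparable step on the core of compound 2, since that core is shown here with neither phenyl nor (4-(diethylamino)piperidin-1-yl)methyl on its carbonyl carbon.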